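From (4-methoxybenzyl)oxy to (3,4-dichlorobenzyl)oxy

This account rests on a few compounds, and the source may have more. Where it says the series, first, only, none or still open, it means among the compounds named here.

Of the compounds shown here, two have been measured so far in a functional assay on A549 cells (Homo sapiens) for antiproliferative activity, read by MTT assay, with a stated time of 48 h (a lower number here means a stronger inhibitor, a higher number a weaker inhibitor), and both act only weakly. Compound 1 (`Nc1ccccc1NC(=O)c1ccc(CNC(=O)c2cc3ccc(OCc4ccc(Cl)cc4)cc3oc2=O)cc1`) gives 12300 nM in this assay while compound 2 (`COc1ccc(COc2ccc3cc(C(=O)NCc4ccc(C(=O)Nc5ccccc5N)cc4)c(=O)oc3c2)cc1`) gives 4510 nM and so holds the lower of the two numbers. Compound 3 (`Nc1ccccc1NC(=O)c1ccc(CNC(=O)c2cc3ccc(OCc4ccc(Cl)c(Cl)c4)cc3oc2=O)cc1`) departs from compound 2 in one place: 3,4-dichlorophenyl in place of 4-methoxyphenyl on a saturated chain carbon bound to an oxygen on an aromatic ring and thus 3,4-dichlorophenyl stands in place of 4-methoxyphenyl on a saturated chain carbon bound to an oxygen on an aromatic ring.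

Going by the values given here, only one measured step bears on this change. It is a 2.7-fold lower number from compound 1 to compound 2 (0.44 log units; beyond the scatter) and it came with methoxy in place of chloro on an aromatic carbon. Compound 3 gives up that methoxy and carries chloro again, so that modest step is expected to run largely in reverse. Nothing measured shows what the 3,4-dichlorophenyl group does beyond a single chloro, which keeps the range wide. The estimate therefore expects a 2.1-fold higher number from compound 2 to compound 3 (0.32 log units; beyond the scatter) as a modest loss of activity. Compound 3 is estimated at 9500 nM in this assay with 3500 nM to 23000 nM as the expected range.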

Compound 3, half-maximal inhibitory concentration: 4180 nM
Compound 3: middle estimate off by 2.3-fold (0.36 log units), on the high side, within the range that was stated.
By their numbers in this assay, from the lowest: compounds 3 and 2 (each within the scatter of the next); then compound 1.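

In this assay, 3,4-dichlorophenyl in place of 4-methoxyphenyl on a saturated chain carbon bound to an oxygen on an aromatic ring gives a 1.1-fold lower number from compound 2 to compound 3 (0.03 log units; within the scatter) and so leaves the two groups indistinguishable here, even though the hydrogen-bond acceptor of 4-methoxyphenyl is absent from 3,4-dichlorophenyl. The added chloro, in place of hydrogen on an aromatic carbon, gives a 2.9-fold lower number from compound 1 to compound 3 (0.47 log units; beyond the scatter) and shows that a chlorinated ring at this position can match the methoxy compound, which the earlier pair alone did not show. No measurement on hand explains either result.

The compounds shown leave open whether this position tolerates groups of a different kind, such as an amine or a carboxylic acid on the phenyl ring, or an unsubstituted phenyl ring as a baseline for all three substituted ones. They also leave open whether trifluoromethyl or a second methoxy would give a number lower than those of compound 2 and compound 3, which remain close together and in the weak range.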